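This account rests on a few compounds, and the source may have more. Where it says the series, first, only, none or still open, it means among the compounds named here.

In an in vivo ADME assay on the whole organism (strain Sprague-Dawley) for pharmacokinetics, with Rattus norvegicus as the target (a higher number here means that more of the compound sits outside the plasma, a lower number that more of the compound stays in the plasma), compound 1 `O=C1[C@@H](NS(=O)(=O)c2ccc3cc(Cl)ccc3c2)CCN1c1ccc2c(c1)CCNC2` gives 3.6 L/kg. Going by the values given here, it has only one measured neighbour, compound 2 `O=C1[C@@H](NS(=O)(=O)c2ccc3cc(Cl)ccc3c2)CCN1c1ccc2c(c1F)CCNC2`, which gives 2.4 L/kg, and repeat measurements could not separate these two numbers. Among the compounds with values here, compound 1 therefore sits level with the only comparison available. Compound 3 `O=C1[C@@H](NS(=O)(=O)c2ccc3cc(Cl)ccc3c2)CCN1c1cc2c(cc1F)CNCC2` keeps the core of compound 1 and makes a single swap: fluoro in place of hydrogen on an aromatic carbon. Within the data shown here, one measured step bears on this change, since compound 2 also carries a fluoro in place of hydrogen on an aromatic carbon, though not on the same carbon as in compound 3. That swap gave a 1.5-fold lower number from compound 1 to compound 2 (0.18 log units; within the scatter). A single example on a different carbon is thin evidence, but it offers no reason to expect a large shift, so no change beyond the scatter is expected in this assay. The estimated step is a 1.2-fold lower number from compound 1 to compound 3 (0.08 log units; within the scatter), a small lean in the direction compound 2 showed. For compound 3 the expected value is 3 L/kg, with an estimated range from 1.6 L/kg to 5.5 L/kg.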

Compound 3, volume of distribution at steady state: 1 L/kg
Beside the measured number, compound 3's estimate is 3.0-fold (0.48 log units) above it, outside the stated range (below it).
By their numbers in this assay, from the lowest: compound 3; then compounds 2 and 1 (each within the scatter of the next).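

The new step shows that this carbon, ortho to a large group, meta to a fused ring and para to a fused ring, is sensitive to the swap in this assay: fluoro in place of hydrogen gives [ a 3.6-fold lower number from compound 1 to compound 3 (0.56 log units; beyond the scatter) ], a change beyond the usual scatter of repeat measurements. The same kind of swap on the different carbon used in compound 2 gave [ a 1.5-fold lower number from compound 1 to compound 2 (0.18 log units; within the scatter) ], which lies within that scatter, so a single added fluoro does not have one fixed outcome across these two carbons. With just these two examples, the result shows that the place of the fluoro can matter here, but it does not amount to a general rule for this series.

Going by these compounds, it remains open whether a different small group on the same carbon, such as methyl, methoxy or nitrile, would move the number as fluoro does. On these data alone, it also remains open whether a compound with fluoro on both carbons would follow compound 3, compound 2 or neither. The data shown contain nothing that explains why the two carbons differ.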